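The source may hold more compounds than are shown below. What is called first, only, known or untested is meant among the compounds shown, and "the series" means these compounds.

Series notes, measured in a functional assay on HepG2 cells (Homo sapiens) for antiproliferative activity, read by MTT assay, with a stated time of 72 h; on this read-out higher numbers stand for weaker inhibition and lower numbers for stronger inhibition:

- compound 1 `COc1ncc(-c2ccc3c(c2)N(c2ccc(C)cc2)C(=O)CO3)cc1NS(=O)(=O)c1ccc(F)cc1` | 28300 nM
- compound 2 `O=C1COc2ccc(-c3cccc(NS(=O)(=O)c4ccc(F)cc4)c3)cc2N1` | > 40000 nM
- compound 3 `COc1ccc(N2C(=O)COc3ccc(-c4ccc(O)cc4)cc32)cc1` | 10800 nM

Compound 2 reads > 40000 nM, which is a limit of the assay and not a number. That leaves two true numbers in this assay. Compound 1 has the higher of them at 28300 nM, and compound 3 gives 10800 nM, a lower number by more than the scatter.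

Next for measurement is compound 4 `COc1cccc(N2C(=O)COc3ccc(-c4cnc(OC)c(NS(=O)(=O)c5ccc(F)cc5)c4)cc32)c1`, which differs from compound 1 in one place: 3-methoxyphenyl in place of 4-methylphenyl on an amide-type nitrogen in a ring. It carries 3-methoxyphenyl in place of 4-methylphenyl on an amide-type nitrogen in a ring, and the rest of the structure is unchanged.

For the measured compounds named here, no measured pair isolates that exchange, so the expectation starts from compound 1 at 28300 nM and leans on nothing else. No step beyond the scatter is expected in this assay, in either direction, and the estimate amounts to a 1.3-fold lower number from compound 1 to compound 4 (0.11 log units; within the scatter) as the expected change. A reading at the limit of the assay remains possible for compound 4. The estimated value for compound 4 is 22000 nM, with an expected range of 10000 nM to 40000 nM as the likely span.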

Compound 4, half-maximal inhibitory concentration: > 40000 nM
Compound 4: no number, only a limit (the forecaster's own chance of this, stated with the estimate: 20%); middle value at least 1.8-fold (0.25 log units) away from the limit.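

In this assay compound 4 gives > 40000 nM, which is a limit of the assay and not a number. For the compounds shown here, this pair is the first to isolate a change on the amide-type nitrogen in a ring: 3-methoxyphenyl in place of 4-methylphenyl gives an at least 1.4-fold higher number from compound 1 to compound 4 (0.15 log units; that floor lies within the scatter), so the exchange yields no lower number, while the floor of the step does not separate the two compounds beyond the scatter. The true size of the step stays unknown because compound 4 sits at the ceiling of the assay, where compound 2 also sits: the limit of > 40000 nM in this assay, at which 2 of the 4 values shown sit.

Still open, going by these compounds, is whether any group on this nitrogen gives a lower number than 4-methylphenyl in the core of compound 1, and an unsubstituted phenyl there would give a plain reference for both aryl groups. Also open, on these data alone, is whether a phenyl carrying an amine or a carboxylic acid at this position would return a true number in this assay, and with it a step of measurable size.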